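Bromophenyl to bromobenzyl on the piperazine-type ring nitrogen

This account rests on a few compounds, and the source may have more. Where it says the series, first, only, none or still open, it means among the compounds named here.

Three members of the series have been measured in an assay on CHO cells for displacement of a labelled ligand from adenosine receptor A3 (Homo sapiens), read by scintillation counting, with a stated time of 45 min, tested at 1 uM, in the presence of a further agent that is not named here; a higher number here means more inhibition at the concentration tested (going by the name of the read-out), a lower number less inhibition. Compound 1 `CCCn1c(=O)[nH]c2nc(-c3ccc(S(=O)(=O)N4CCN(Cc5ccc(Br)cc5)CC4)cc3)[nH]c2c1=O` gives 28%, compound 2 `CCCn1c(=O)[nH]c2nc(-c3ccc(S(=O)(=O)N4CCN(c5ccccc5Br)CC4)cc3)[nH]c2c1=O` gives 20%, and compound 3 `CCCn1c(=O)[nH]c2nc(-c3ccc(S(=O)(=O)N4CCN(c5ccccc5Cl)CC4)cc3)[nH]c2c1=O` gives 32%. Compound 2 has the lowest of the three numbers: its nearest neighbour is compound 1, the step of a number 8 percentage points lower from compound 1 to compound 2 (within the scatter) lying within the scatter, while the step to compound 3 a number 12 percentage points higher from compound 2 to compound 3 (beyond the scatter) lies beyond it.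

The next compound, compound 4 `CCCn1c(=O)[nH]c2nc(-c3ccc(S(=O)(=O)N4CCN(Cc5cccc(Br)c5)CC4)cc3)[nH]c2c1=O`, differs from compound 2 in one place: 3-bromobenzyl in place of 2-bromophenyl on an amine nitrogen in a ring.

Within the data shown here, the step that bears most directly on this change is the one from compound 1 to compound 2 a number 8 percentage points lower from compound 1 to compound 2 (within the scatter), where a bromophenyl replaced a bromobenzyl on the same ring nitrogen without moving the number beyond the scatter. The parallel step to compound 3 a number 4 percentage points higher from compound 1 to compound 3 (within the scatter) was likewise within the scatter. Going from compound 2 to compound 4 reverses the phenyl-to-benzyl direction, so in this assay no more than a small shift is expected, if anything upward toward the numbers of compound 1 and compound 3.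

The step implied by this is expected to be a number 7 percentage points higher from compound 2 to compound 4 (within the scatter), within the scatter. Compound 4 is therefore estimated at 27%, with a range from 15% to 40%.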

Compound 4, a percentage reported as inhibition, at one concentration (the size of the read-out at that concentration, not a potency): 23%
Compound 4: middle estimate off by 4 percentage points, on the high side; low and high end bracket the measured number.
By their numbers in this assay, from the lowest: compounds 2, 4, 1 and 3 (each within the scatter of the next, the first and the last beyond it).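

In this assay, among these compounds, the change from 2-bromophenyl to 3-bromobenzyl on the amine nitrogen in a ring gives a step that can be read directly (a number 3 percentage points higher from compound 2 to compound 4 (within the scatter)), and moving the bromine from the 4-bromobenzyl group to the 3-bromobenzyl group gives the first reading of bromine placement on the benzyl group (a number 5 percentage points lower from compound 1 to compound 4 (within the scatter)). The comparison with the 2-chlorophenyl group (a number 9 percentage points lower from compound 3 to compound 4 (within the scatter)) also stays inside the scatter, so compound 4 lies within the scatter of all three other compounds, and across these groups only the chloro and bromo pair on the phenyl group remains separated beyond it. No independent data on these compounds offer an explanation for the numbers.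

From the compounds shown here alone, whether a 2-bromobenzyl group would complete the bromine comparison on the benzyl group remains open, as does whether an amine or a carboxylic acid on the benzyl ring would carry the number beyond the scatter. These readings at one concentration also leave the relative potency of the four compounds unresolved.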